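The compounds below may be only part of what the source reports. "The series", "measured", "known", "first", "only" and "open" are said of these compounds alone.

Three compounds that share one core were examined in a functional assay on SV5A8 cells (Homo sapiens) for cytotoxicity (on this read-out higher numbers stand for weaker inhibition and lower numbers for stronger inhibition), and a fourth still awaits its number. Among the measured compounds shown here, compound 1 `Cc1ccc2c(NCc3ccc(NC(=O)C4CCN(Cc5cc(Cl)ccn5)CC4)cc3)nc(N(C)C)nc2c1` is the first of them. In this assay compound 1 gives only a limit, > 5400 nM. Compound 3 `Cc1ccc2c(NCc3ccc(NC(=O)C4CCN(CC5CCNCC5)CC4)cc3)nc(N(C)C)nc2c1` is its close relative. In this assay compound 3 also gives only a limit, > 8070 nM. The step that the two limits leave unreadable from compound 1 to compound 3 is therefore of no readable size. Compound 2 `Cc1ccc2c(NCc3ccc(NC(=O)C4CCN(Cc5ccccc5)CC4)cc3)nc(N3CCNC(CCO)C3)nc2c1` is the third measured member. In this assay compound 2 likewise stands at a limit, > 8420 nM, so only a limit or a range is known for it. Of the three values shown, one sits at the limit of > 5400 nM in this assay, at which 1 of the 3 values shown sits, one at the limit of > 8070 nM in this assay, at which 1 of the 3 values shown sits, and one at the limit of > 8420 nM in this assay, at which 1 of the 3 values shown sits.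

The compound not yet measured is compound 4 `CCN1CCN(c2nc(NCc3ccc(NC(=O)C4CCN(Cc5ccccc5)CC4)cc3)c3ccc(C)cc3n2)CC1`. Compared with compound 2 the difference is 4-ethylpiperazin-1-yl in place of 3-(2-hydroxyethyl)piperazin-1-yl on an aromatic carbon. For the measured compounds named here, no measured step touches this position, and the only step available cannot be sized, so there is nothing to suggest a change beyond the scatter. Compound 4 is therefore expected to show a step that the limit leaves unreadable from compound 2 to compound 4 of no size beyond the scatter. The estimate for compound 4 is 9000 nM, ranging from 3000 nM to 30000 nM, most likely again reported as a limit.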

Compound 4, half-maximal inhibitory concentration: > 13000 nM
Compound 4: a limit, no number (the forecaster's own chance of this, stated with the estimate: 80%); at least 1.4-fold (0.15 log units) between middle value and limit.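

In this assay compound 4 gives only a limit, > 13000 nM. Compound 2 also stands at a limit, so the step from compound 2 to compound 4 cannot be read. The compounds shown leave open what number any of the four would give in this assay, and whether 4-ethylpiperazin-1-yl in place of 3-(2-hydroxyethyl)piperazin-1-yl changes anything.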